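The compounds below may be only part of what the source reports. "The series", "measured", "known", "first", "only" and "open" are said of these compounds alone.

Three compounds sharing one core were measured in a functional assay on the whole organism for inhibition, with Mus musculus as the target; a higher number here means that more compound is needed for the effect, a lower number that less compound is needed. Compound 1 (`CCC1CCSC1=O`) gives 414 mg/kg, compound 2 (`CC(C)C1CCSC1=O`) gives 145 mg/kg, and compound 3 (`CC(C)(C)C1CCSC1=O`) gives 244 mg/kg. Compound 2 sits at the low end of this small set: compound 3 cannot be told apart from it, and only compound 1 lies beyond the scatter from it.

The next compound to be measured is compound 4 (`CC(C)C1(C(C)C)CCSC1=O`), which carries isopropyl in place of hydrogen on a saturated ring carbon of compound 2: isopropyl in place of hydrogen on a saturated ring carbon. Two measured steps offer some guidance. The first is a 2.9-fold lower number from compound 1 to compound 2 (0.46 log units; beyond the scatter), and the second is a 1.7-fold higher number from compound 2 to compound 3 (0.23 log units; within the scatter). Among the measured compounds shown here, both place methyl on a saturated chain carbon, so neither tests a change on the ring carbon, and the data hold no direct precedent for it. They show only that added methyl has so far moved this assay modestly or not beyond the scatter. A similarly small change is therefore expected here, with the direction only weakly supported, and the estimated step is a 1.3-fold lower number from compound 2 to compound 4 (0.12 log units; within the scatter). For compound 4 the expected value is 110 mg/kg, with an estimated range from 35 mg/kg to 330 mg/kg.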

Compound 4, dose for half-maximal effect: > 500 mg/kg
Compound 4 was reported as a limit; the forecaster's own chance of this, stated with the estimate: 15%; middle value at least 4.5-fold (0.65 log units) from the limit.
By their numbers in this assay, from the lowest: compounds 2, 3 and 1 (each within the scatter of the next, the first and the last beyond it). At a limit, above all of these: compound 4.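

Isopropyl in place of hydrogen on a saturated ring carbon, two ring bonds from the ring sulfur, is the only change at this position among these compounds, and in this assay it gives an at least 3.4-fold higher number from compound 2 to compound 4 (0.53 log units; beyond the scatter). Among the compounds shown here, the earlier steps, both methyl in place of hydrogen on a saturated chain carbon, gave a 2.9-fold lower number from compound 1 to compound 2 (0.46 log units; beyond the scatter) and a 1.7-fold higher number from compound 2 to compound 3 (0.23 log units; within the scatter), so this ring carbon is the first place in the set where a change raises the number beyond the scatter. Compound 4 gives > 500 mg/kg, which is a limit of the assay, and it is the only compound in the set that stands at such a limit: the limit of > 500 mg/kg in this assay, at which 1 of the 4 values shown sits.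

With isopropyl as the only group shown on this ring carbon, the compounds leave open whether the rise belongs to isopropyl itself or would also follow from a smaller group such as methyl in the same place. They also leave open how a hydroxyl, an amine or a carboxylic acid on this ring carbon would read in this assay.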